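This account rests on a few compounds, and the source may have more. Where it says the series, first, only, none or still open, it means among the compounds named here.

Working notes on the thiazole acetic acid series.

Compound 1 `O=C(O)Cc1sc(C(c2ccc(F)cc2)c2ccc(F)cc2)nc1-c1ccnc(F)c1` gives 4.7 nM in an in vitro functional assay on HEK285-7 cells for antagonist activity at prostaglandin D2 receptor 2 (Homo sapiens), read by BRET and beta-arrestin recruitment; a lower number here means a stronger inhibitor, a higher number a weaker inhibitor. Compound 2 `O=C(O)Cc1sc(C(c2ccc(F)cc2)c2ccc(F)cc2)nc1-c1cc(F)nc(F)c1` gives 110 nM, a step of a 23-fold higher number from compound 1 to compound 2 (1.37 log units; beyond the scatter). Compound 3 `O=C(O)Cc1sc(C(c2ccc(F)cc2)c2ccc(F)cc2)nc1-c1cn[nH]c1` gives 220 nM, the highest of the three numbers; its step from compound 1 is a 47-fold higher number from compound 1 to compound 3 (1.67 log units; beyond the scatter), while a 2.0-fold higher number from compound 2 to compound 3 (0.30 log units; within the scatter) keeps compound 2 and compound 3 within the scatter of each other.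

Compound 4 `O=C(O)Cc1sc(C(c2ccc(F)cc2)c2ccc(F)cc2)nc1-c1ccnc(Cl)c1` is not yet measured. It differs from compound 3 by 2-chloropyridin-4-yl in place of 1H-pyrazol-4-yl on an aromatic carbon, on the aromatic carbon next to the ring nitrogen of the shared core. Within the data shown here, the one step that bears on this is a 47-fold higher number from compound 1 to compound 3 (1.67 log units; beyond the scatter), since compound 1 carries 2-fluoropyridin-4-yl at the same place. Reversing it, a large drop is expected in this assay, a 31-fold lower number from compound 3 to compound 4 (1.50 log units; beyond the scatter), giving an estimate for compound 4 of 7 nM (range 2 nM to 30 nM).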

Compound 4, half-maximal inhibitory concentration: 39 nM
For compound 4 the middle estimate is 5.6-fold (0.75 log units) below the measured one; the whole stated range lies below it.
By their numbers in this assay, from the lowest: compound 1; then compound 4; then compounds 2 and 3 (each within the scatter of the next).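

Swapping the halogen at this position is not neutral: chloro in place of fluoro gives an 8.3-fold higher number from compound 1 to compound 4 (0.92 log units; beyond the scatter) in this assay and leaves the 2-fluoropyridin-4-yl group of compound 1 ahead. The 2-chloropyridin-4-yl group still holds an advantage over the other two replacements, with a 5.6-fold lower number from compound 3 to compound 4 (0.75 log units; beyond the scatter) and with a 2.8-fold lower number from compound 2 to compound 4 (0.45 log units; beyond the scatter) as well. No measurement here explains these differences.

On these data alone, it remains open whether a methyl, a methoxy or an amine in place of the chloro would bring the number back towards that of compound 1. As far as these compounds go, whether the same order of groups holds with another substituent in place of the carboxymethyl group also remains open.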